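Benzimidazole-linked amides: dimethylamino in place of chloro-trifluoromethyl

The source may report more compounds than this note shows. Statements on the series, on what has been measured and on what is new or still open speak of the compounds shown alone.

Three compounds carry the same isoquinoline sulfonate ester. In an assay on THP-1 cells for antagonist activity at P2X purinoceptor 7 (Homo sapiens), read by ELISA, with a stated time of 30 min (a lower number here means a stronger inhibitor, a higher number a weaker inhibitor), compound 1 `O=C(c1ccc(Cl)c(C(F)(F)F)c1)N1CCC(n2cncc2-c2ccc(OS(=O)(=O)c3cccc4cnccc34)cc2)CC1` gives 22 nM and compound 2 `O=C(c1ccc([N+](=O)[O-])cc1)N1CCN(c2cc(=O)[nH]c(=O)n2Cc2ccc(OS(=O)(=O)c3cccc4cnccc34)cc2)CC1` gives 32 nM. Compound 3 `O=C(c1ccc(Cl)c(C(F)(F)F)c1)N1CCC(c2nc3cc(OS(=O)(=O)c4cccc5cnccc45)ccc3[nH]2)CC1` gives 210 nM in this assay, the highest of the three numbers, and the gaps to compound 2 and compound 1 both lie beyond the scatter.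

Compound 4 `CN(C)c1ccc(C(=O)N2CCC(c3nc4cc(OS(=O)(=O)c5cccc6cnccc56)ccc4[nH]3)CC2)cc1` differs from compound 3 in one place: 4-(dimethylamino)phenyl in place of 4-chloro-3-(trifluoromethyl)phenyl on a carbonyl carbon. Going by the values given here, no measured pair shows this exchange, so no direction can be read from the series. The step from compound 3 to compound 4 is expected to stay within the scatter, estimated as a 1.4-fold higher number from compound 3 to compound 4 (0.15 log units; within the scatter). Compound 4 is therefore estimated at 300 nM in this assay, with a range from 100 nM to 1000 nM.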

Compound 4, half-maximal inhibitory concentration: 121 nM
Beside the measured number, compound 4's estimate is 2.5-fold (0.39 log units) above it; the measured number falls inside the stated range.
By their numbers in this assay, from the lowest: compounds 1 and 2 (each within the scatter of the next); then compounds 4 and 3 (each within the scatter of the next).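

In this assay, going by these compounds alone, the first one-place step is a 1.7-fold lower number from compound 3 to compound 4 (0.24 log units; within the scatter), so the aryl group on this carbonyl carbon accepts 4-(dimethylamino)phenyl for 4-chloro-3-(trifluoromethyl)phenyl with both compounds staying within the scatter of each other. Neither the chlorine nor the trifluoromethyl group is needed here to hold the number in this range. Nothing on hand explains this outcome.

As far as these compounds go, whether a non-aromatic group such as cyclohexyl, or a carboxylic acid on the phenyl ring, would be accepted at this position remains open. So does whether the same exchange on the core of compound 1 gives a similar step.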